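Swapping a Pyridine for a Thiazole on the Thioether

This account rests on a few compounds, and the source may have more. Where it says the series, first, only, none or still open, it means among the compounds named here.

Compound 1: `CN(Cc1cc(=O)oc2cc(O)ccc12)c1ccccc1`; in an assay on HeLa cells for inhibition of 17-beta-hydroxysteroid dehydrogenase type 3 (Homo sapiens) (a lower number here means a stronger inhibitor, a higher number a weaker inhibitor), compound 1 gives 6000 nM
Compound 2: `O=c1cc(CSc2ccncc2)c2ccc(O)cc2o1`; in this assay compound 2 gives 5000 nM

Both measured compounds carry the shared core with a hydroxy group, and differ in the side chain attached to it. The two values sit close together: the number for compound 2 is the lower of the two, but the gap to compound 1 lies within the scatter of repeated measurements, so neither compound can be called the stronger inhibitor on this evidence.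

Compound 3, `O=c1cc(CSc2nccs2)c2ccc(O)cc2o1`, is built from compound 2 by 1,3-thiazol-2-yl in place of pyridin-4-yl on a sulfur. Within the data shown here, no measured pair shows what such an exchange does in this assay, so there is nothing to support a shift in either direction; the expected step from compound 2 to compound 3 is none beyond the scatter. Compound 3 is therefore estimated at 5000 nM, with a range from 1500 nM to 16000 nM, which corresponds to an expected step of no change at the digits printed from compound 2 to compound 3 (within the scatter).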

Compound 3, half-maximal inhibitory concentration: 10 nM
Compound 3: middle estimate off by 500-fold (2.70 log units), on the high side; the measured number lies below the stated range.
By their numbers in this assay, from the lowest: compound 3; then compounds 2 and 1 (each within the scatter of the next).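

The group on the sulfur matters far more in this assay than the close values of compound 1 and compound 2 could suggest: putting 1,3-thiazol-2-yl in place of pyridin-4-yl gives a 500-fold lower number from compound 2 to compound 3 (2.70 log units; beyond the scatter) while the shared core and the saturated chain carbon on the sulfur stay the same. This position is therefore highly sensitive to which aromatic ring it carries, as a six-membered ring with 1 hetero atom gives way to a five-membered ring with 2 hetero atoms. Nothing available explains this large step.

Among these compounds, the single exchange changes ring size and hetero atoms together, so it cannot show which of these differences accounts for the step. On these data alone, it remains open whether a thiophen-2-yl or 1,3-oxazol-2-yl group on the same sulfur would keep the number as low, or whether an oxygen could replace that sulfur.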